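The compounds below may be only part of what the source reports. "The series", "measured", "known", "first", "only" and "open" are said of these compounds alone.

Three compounds sharing a pyridazinone core carrying a substituted side chain have been tested in a functional assay on the whole organism with Rattus norvegicus as the target, at a dose of 100 mg/kg; a lower number here means less inhibition, a higher number more inhibition at the dose given (going by the name of the read-out). Compound 1 `C/N=C(/NC#N)NCCCn1nc(-c2ccccc2)ccc1=O` gives 40.5% in this assay. For the measured compounds named here, compound 3 `CC(C)(C)/N=C(\S)NCCCCn1nc(-c2ccccc2)ccc1=O` gives 33.6%, a number that sits within the usual scatter of the one for compound 1, so the two cannot be told apart. Compound 2 `C/N=C(/NC#N)NCCCCn1nc(N2CCCC2)ccc1=O`, in which the phenyl group on the core is replaced and the chain is lengthened, gives -1%, a number well beyond the scatter below compound 1. On the numbers shown, compound 1 thus has the highest figure, although its separation from compound 3 is not meaningful.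

Compound 4 `CC/N=C(/NC#N)NCCCn1nc(-c2ccccc2)ccc1=O` is not yet measured. It differs from compound 1 in one place: methyl in place of hydrogen on a saturated chain carbon bound to a double-bonded nitrogen. Going by the values given here, no measured pair shows the effect of this change, so there is nothing to anchor a direction. A small group added at the far end of the chain is expected to move the inhibition little, and the step of a number 2.5 percentage points lower from compound 1 to compound 4 (within the scatter) is estimated to lie within the scatter. For compound 4 an inhibition of 38% is expected, in the range 20% to 55%.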

Compound 4, a percentage reported as inhibition, in the whole organism at one dose (the size of the read-out at that dose, not a potency): 62.9%
Beside the measured number, compound 4's estimate is 24.9 percentage points below it; measured number above the stated range.
By their numbers in this assay, from the lowest: compound 2; then compounds 3 and 1 (each within the scatter of the next); then compound 4.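

In this assay, the change of methyl to ethyl on a saturated chain carbon bound to a double-bonded nitrogen comes with a number 22.4 percentage points higher from compound 1 to compound 4 (beyond the scatter). For the compounds shown here, this place is therefore not silent: one added carbon is enough to separate two compounds, something the earlier compounds could not show, as no two of them differed in one place only. Nothing measured here accounts for this step, so it stands as an observation without an explanation.

The compounds shown leave open whether the number keeps rising with a longer chain such as propyl, or with a branched group such as isopropyl, at this same place. Also open, on these data alone, is whether the step carries over to other compounds, since it rests on a single pair.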